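A Chlorophenyl Amide Variant of Compound 1

A few compounds are considered here, and "the series" means these few. Any claim that something is new, unique, unknown or untested is made for them only; others in the source may bear on it.

Compound 1 `O=C(Nc1cc(Sc2ncn[nH]2)c(O)c2ccccc12)c1ccc([N+](=O)[O-])cc1` gives 37.3% in an assay on isolated protein for inhibition of RAC-alpha serine/threonine-protein kinase (Homo sapiens), read by fluorescence, with a stated time of 30 min, tested at 10 uM (on this read-out higher numbers stand for more inhibition at the one concentration tested (going by the name of the read-out) and lower numbers for less inhibition), the higher of the two numbers measured here. Compound 2 `O=C(Nc1cc(Sc2ncnc3nc[nH]c23)c(O)c2ccccc12)c1ccc(Cl)cc1` gives 21.7% in this assay, a number that sits below compound 1 by more than the usual scatter. Compound 3 `O=C(Nc1cc(Sc2ncn[nH]2)c(O)c2ccccc12)c1cccc(Cl)c1` has not yet been measured and differs from compound 1 by 3-chlorophenyl in place of 4-nitrophenyl on a carbonyl carbon. For the measured compounds named here, no measured pair isolates this change, so its size is unknown. The step of a number 7.3 percentage points lower from compound 1 to compound 3 (within the scatter) is expected to be small and downward, not beyond the scatter. Compound 3 is therefore estimated to give 30% in this assay, within 10% to 50%.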

Compound 3, a percentage reported as inhibition, at one concentration (the size of the read-out at that concentration, not a potency): 46%
Compound 3: middle estimate off by 16 percentage points, on the low side, and the stated range covers the measured number.
By their numbers in this assay, from the lowest: compound 2; then compounds 1 and 3 (each within the scatter of the next).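

In this assay, for the compounds shown here, 3-chlorophenyl in place of 4-nitrophenyl on a carbonyl carbon gives a number 8.7 percentage points higher from compound 1 to compound 3 (within the scatter), the only step read at this position. The hydrogen-bond acceptors counted on 4-nitrophenyl are absent from 3-chlorophenyl, yet the two numbers stay within the scatter of each other. No measurement at hand bears on a cause for this result.

This single step changes both the group on the phenyl ring and its ring position, so the two cannot be separated. Going by these compounds, how a phenyl carrying an amine or a carboxylic acid would read at this carbonyl carbon remains open.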